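Carboxybenzyl positional isomer on the pyrazole nitrogen

The source may hold more compounds than are shown below. What is called first, only, known or untested is meant among the compounds shown, and "the series" means these compounds.

Measured compounds:
- Compound 1 `CCC(CC)N(CCN(C)C(=O)CCC(=O)O)Cc1cccc(C(=O)Nc2sc3c(c2C(=O)c2cnn(-c4cccc(C(F)(F)F)c4)c2)CCC(C)(C)C3)c1`: in an assay on isolated protein for inhibition of sodium-dependent phosphate transport protein 2B (Homo sapiens) (a higher number here means a weaker inhibitor, a lower number a stronger inhibitor), compound 1 gives 46 nM.
- Compound 2 `CCC(CC)N(CCN(C)C(=O)CCC(=O)O)Cc1cccc(C(=O)Nc2sc3c(c2C(=O)c2cnn(Cc4ccc(C(=O)O)cc4)c2)CCC(C)(C)C3)c1`: in this assay compound 2 reports only a limit, > 1000 nM.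

Compound 2 thus sits at the limit of this assay (the limit of > 1000 nM in this assay, at which 1 of the 2 values shown sits), with no number of its own. Going by the values given here, the one measured step, an at least 21-fold higher number from compound 1 to compound 2 (1.33 log units; beyond the scatter), is the only step bearing on the next change. Compound 3 `CCC(CC)N(CCN(C)C(=O)CCC(=O)O)Cc1cccc(C(=O)Nc2sc3c(c2C(=O)c2cnn(Cc4cccc(C(=O)O)c4)c2)CCC(C)(C)C3)c1` differs from compound 2 by 3-carboxyphenyl in place of 4-carboxyphenyl on a saturated chain carbon bound to an aromatic nitrogen. The carboxybenzyl group that ended compound 2 at the limit remains, so no step beyond the scatter is expected; compound 3 is estimated at 2500 nM (600 nM to 10000 nM), an expected change of a step that the limit leaves unreadable from compound 2 to compound 3.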

Compound 3, half-maximal inhibitory concentration: > 1000 nM
Compound 3: no number, only a limit (the forecaster's own chance of this, stated with the estimate: 70%); the middle value lies beyond the limit too.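

The 3-carboxybenzyl group on the aromatic nitrogen also gives an at least 21-fold higher number from compound 1 to compound 3 (1.33 log units; beyond the scatter), so the loss against the 3-(trifluoromethyl)phenyl of compound 1 is not confined to the 4-carboxybenzyl isomer. The step between the two carboxybenzyl isomers cannot be read, since neither has a number of its own, only a limit: the limit of > 1000 nM in this assay, at which 2 of the 3 values shown sit.

Still open, from the compounds shown here alone, is how much of the loss belongs to the carboxylic acid and how much to the benzyl link. A plain benzyl or a 3-(trifluoromethyl)benzyl on the same nitrogen would separate the two.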